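Triazolyl dithiocarbamates: cell-growth inhibition notes

The source may hold more compounds than are shown below. What is called first, only, known or untested is meant among the compounds shown, and "the series" means these compounds.

Measured compounds:
compound 1, `CC(C)(C)OC(=O)N1CCN(C(=S)SCc2cn(-c3ccccc3F)nn2)CC1`: 89600 nM
compound 2, `COc1cc(Cn2cc(CSC(=S)N3CCN(C(=O)OCc4ccccc4)CC3)nn2)cc(OC)c1OC`: limit only, > 128000 nM
compound 3, `S=C(SCc1cn(Cc2ccc(Cl)c(Cl)c2)nn1)N1CCNCC1`: "not determined" (no result reported)

Among the measured compounds shown here, in a functional assay on MCF7 cells (Homo sapiens) for inhibition, read by MTT assay, with a stated time of 72 h (on this read-out lower numbers stand for stronger inhibition and higher numbers for weaker inhibition), compound 1 gives 89600 nM, the only single number in the set. For compound 2 this assay reports only a limit, > 128000 nM. The entry of compound 2 is the limit of > 128000 nM in this assay, at which 1 of the 3 values shown sits. For compound 3 this assay reports "not determined" (no result reported), that is no result, so compound 1 cannot be ordered against either neighbour.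

Compound 4, `CC(C)(C)OC(=O)N1CCN(C(=S)SCc2cn(Cc3ccccc3Cl)nn2)CC1`, differs from compound 1 by 2-chlorobenzyl in place of 2-fluorophenyl on an aromatic nitrogen, in words 2-chlorobenzyl in place of 2-fluorophenyl on an aromatic nitrogen. For the measured compounds named here, no step between measured compounds speaks to this change, so no shift beyond the usual scatter is expected in either direction. Compound 4 is expected to give 80000 nM in this assay, within the range 30000 nM to 200000 nM. The step of a 1.1-fold lower number from compound 1 to compound 4 (0.05 log units; within the scatter) is estimated to stay inside the scatter.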

Compound 4, half-maximal inhibitory concentration: 6090 nM
For compound 4 the middle estimate is 13-fold (1.12 log units) above the measured one; the measured number lies below the stated range.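

In this assay, 2-chlorobenzyl in place of 2-fluorophenyl on an aromatic nitrogen gives a 15-fold lower number from compound 1 to compound 4 (1.17 log units; beyond the scatter), so the group at this position matters in this series. The change alters both the halogen and the link to the ring, and the step cannot separate the two. Nothing among the data shown bears on why the number moves.

Open, as far as these compounds go, is which part of the change carries the step, a question that 2-chlorophenyl or 2-fluorobenzyl at this position would address. Also open, from the compounds shown here alone, is how a longer chain between the nitrogen and the ring, or an amine on the ring, would read.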